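A few compounds are considered here, and "the series" means these few. Any claim that something is new, unique, unknown or untested is made for them only; others in the source may bear on it.

Measured so far: compound 2, `Cc1c(C(C)OC(=O)Nc2ccccc2)oc2nc(Cl)nn12`, 10 nM; compound 1, `Cc1c(C(C)OC(=O)Nc2ccc(Cl)c(Cl)c2)oc2ncnn12`, 5010 nM.

In a functional assay on CHO cells for antagonist activity at metabotropic glutamate receptor 5 (Homo sapiens), read by calcium flux (a lower number here means a stronger inhibitor, a higher number a weaker inhibitor), compound 2 gives 10 nM, the lowest of the two numbers, while compound 1 gives 5010 nM; the two differ in more than one place, so only their values are compared. Compound 3, `Cc1c(C(C)OC(=O)Nc2ccccc2)oc2nc(C(F)(F)F)nn12`, carries trifluoromethyl in place of chloro on an aromatic carbon. Within the data shown here, no measured pair shows this exchange, so no direction can be read from the data. Compound 3 is expected at 15 nM, within 5 nM to 60 nM. The expected step is a 1.5-fold higher number from compound 2 to compound 3 (0.18 log units; within the scatter), not beyond the scatter.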

Compound 3, half-maximal inhibitory concentration: 39.8 nM
For compound 3 the middle estimate is 2.7-fold (0.42 log units) below the measured one; measured number inside the range.
By their numbers in this assay, from the lowest: compound 2; then compound 3; then compound 1.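

In this assay, among these compounds, trifluoromethyl in place of chloro on this aromatic carbon gives a 4.0-fold higher number from compound 2 to compound 3 (0.60 log units; beyond the scatter), the first single exchange that can be read at this position. Four heavy atoms replacing one cost only a modest step here, and the order favours chloro. Nothing available explains this step. The compounds shown leave open how a methyl group, a nitrile or an amine on this carbon would compare with chloro. They also leave open whether the step would keep its size alongside the other differences that compound 1 carries.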